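This account rests on a few compounds, and the source may have more. Where it says the series, first, only, none or still open, it means among the compounds named here.

In a functional assay on cells (T-cell, Mus musculus, strain BALB/c) for inhibition, read by MTT assay, with a stated time of 72 h (on this read-out lower numbers stand for stronger inhibition and higher numbers for weaker inhibition), the measured compounds are compound 1 `COC(=O)c1c(F)cccc1OC(=O)COc1cc(O)c2c(=O)cc(-c3ccccc3)oc2c1` at 40300 nM, compound 2 `COC(=O)c1ccc(C)cc1OC(=O)COc1cc(O)c2c(=O)cc(-c3ccccc3)oc2c1` at 31100 nM, and compound 3 `COC(=O)c1ccc(Cl)cc1OC(=O)COc1cc(O)c2c(=O)cc(-c3ccccc3)oc2c1` at 12400 nM.

Compound 2 holds the second highest of the three numbers: its nearest neighbour is compound 1, with a 1.3-fold lower number from compound 1 to compound 2 (0.11 log units; within the scatter), and its furthest is compound 3, with a 2.5-fold lower number from compound 2 to compound 3 (0.40 log units; beyond the scatter).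

Compound 4 `COC(=O)c1c(Cl)cccc1OC(=O)COc1cc(O)c2c(=O)cc(-c3ccccc3)oc2c1` differs from compound 2 by a group of 11 heavy atoms (8 carbon, 2 oxygen, 1 chlorine; one six-membered aromatic ring of carbon only) in place of a group of 11 heavy atoms (9 carbon, 2 oxygen; one six-membered aromatic ring of carbon only), on an oxygen next to a carbonyl group. Among the measured compounds shown here, two measured steps bear on this: a 2.5-fold lower number from compound 2 to compound 3 (0.40 log units; beyond the scatter) shows chloro in place of methyl bringing a modest gain, yet a 3.3-fold lower number from compound 1 to compound 3 (0.51 log units; beyond the scatter) shows the position of the halogen mattering as well, with compound 1 giving the highest number of the set. Compound 4 is therefore expected to move only a little from compound 2, as a 1.2-fold lower number from compound 2 to compound 4 (0.08 log units; within the scatter), with an estimated 26000 nM spanning 11000 nM to 60000 nM.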

Compound 4, half-maximal inhibitory concentration: 38900 nM
Estimate against measurement, compound 4: 1.5-fold (0.17 log units) below; the range from low to high includes it.
By their numbers in this assay, from the lowest: compound 3; then compounds 2, 4 and 1 (each within the scatter of the next).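

In this assay, where the chlorine sits matters more than which group is exchanged: the 3-chloro-2-(methoxycarbonyl)phenyl group of compound 4 gives a weaker result than the 5-chloro-2-(methoxycarbonyl)phenyl group (a 3.1-fold higher number from compound 3 to compound 4 (0.50 log units; beyond the scatter)). Chlorine alone therefore does not carry the gain seen with compound 3. The other two steps stay within the scatter, for the exchange of the methyl-bearing group (a 1.3-fold higher number from compound 2 to compound 4 (0.10 log units; within the scatter)) and for the exchange of one halogen for the other (a 1.0-fold lower number from compound 1 to compound 4 (0.02 log units; within the scatter)). Nothing available explains these differences. Still open, going by these compounds, is how an amine or a nitrile on this aromatic ring would read, and whether a carboxylic acid in place of the methoxycarbonyl group would hold the number of compound 3.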